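Dropping the Methoxy Group: What to Expect for Compound 3

The compounds below may be only part of what the source reports. "The series", "measured", "known", "first", "only" and "open" are said of these compounds alone.

Of the compounds shown here, two sharing one core have so far been tested in a functional assay on K562 cells (Homo sapiens) for inhibition, read by sulforhodamine B assay, with a stated time of 48 h; a lower number here means a stronger inhibitor of growth, a higher number a weaker inhibitor of growth. Compound 1 `COc1ccc(-c2ccc(-c3ccc(C(=N)N)o3)o2)cc1` gives 490 nM, while compound 2 `COc1cc(OC)cc(-c2ccc(-c3ccc(C(=N)N)o3)o2)c1`, which carries two methoxy groups, gives 1980 nM. Compound 1 therefore stands as the lower of the two numbers, and its gap to compound 2 lies beyond the usual scatter of repeated measurements.

Compound 3 `N=C(N)c1ccc(-c2ccc(-c3ccccc3)o2)o1` has not yet been measured. It differs from compound 1 in one place: hydrogen in place of methoxy on an aromatic carbon. Within the data shown here, the only comparison available, between compound 1 and compound 2, concerns adding a second methoxy rather than removing the first, so it offers no direct guide to this step. Compound 3 is expected to give about 700 nM, with a range from 250 nM to 2000 nM. That estimate corresponds to an expected step of a 1.4-fold higher number from compound 1 to compound 3 (0.15 log units; within the scatter), a small shift toward a higher number, not clearly beyond the scatter.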

Compound 3, concentration for 50% growth inhibition: 660 nM
For compound 3 the middle estimate is 1.1-fold (0.03 log units) above the measured one, and the stated range covers the measured number.
By their numbers in this assay, from the lowest: compounds 1 and 3 (each within the scatter of the next); then compound 2.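

Swapping the methoxy group for hydrogen gives in this assay a 1.3-fold higher number from compound 1 to compound 3 (0.13 log units; within the scatter) and so leaves compound 1 and compound 3 indistinguishable in this growth-inhibition test. Among these compounds, this adds something the earlier compounds could not show: on this aromatic carbon, para to a large group, growth inhibition in this range does not depend on the methoxy group, and plain hydrogen serves as well. No supporting data on hand explain why this change makes so little difference.

The compounds shown leave open whether an amine, a carboxylic acid or a longer chain at this same place would also keep the number in this range or shift it beyond the scatter. They also leave open whether hydrogen and methoxy would match as closely on a core other than the shared one.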